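Benzoyl for phenyl on the sulfur chain of compound 3

This account rests on a few compounds, and the source may have more. Where it says the series, first, only, none or still open, it means among the compounds named here.

Measured so far:
Compound 1 `CCSc1nnc(-c2cc(OC)c(OC)c(OC)c2)n1-c1ccc(OC)cc1`: > 60000 nM (a limit)
Compound 2 `COc1ccc(-n2c(SCc3ccccc3)nnc2-c2cc(OC)c(OC)c(OC)c2)cc1`: > 60000 nM (a limit)
Compound 3 `COc1cc(-c2nnc(SCc3ccccc3)n2-c2ccc(N(C)C)cc2)cc(OC)c1OC`: > 60000 nM (a limit)

In a functional assay on HT-29 cells (Homo sapiens) for inhibition, read by MTT assay, with a stated time of 48 h (a higher number here means a weaker inhibitor, a lower number a stronger inhibitor), compound 3 gives > 60000 nM, which is a limit and not a number. All three compounds share (the limit of > 60000 nM in this assay, at which 3 of the 3 values shown sit). Compound 4 `COc1cc(-c2nnc(SCC(=O)c3ccccc3)n2-c2ccc(N(C)C)cc2)cc(OC)c1OC` carries benzoyl in place of phenyl on a saturated chain carbon bound to a sulfur. The nearest measured change, at that same place, is a step that the two limits leave unreadable from compound 1 to compound 2. The other is a step that the two limits leave unreadable from compound 2 to compound 3. Neither offers a size to carry over, so an at least 2.0-fold lower number from compound 3 to compound 4 (0.30 log units; that floor lies within the scatter) is expected only tentatively, leaning towards a stronger inhibitor, and a further limit remains quite possible. Compound 4 is estimated at 30000 nM, with an expected range of 1000 nM to 60000 nM.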

Compound 4, half-maximal inhibitory concentration: 45200 nM
Beside the measured number, compound 4's estimate is 1.5-fold (0.18 log units) below it, within the range that was stated.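

In this assay, compound 4 is the only compound shown that gives a number and not a limit: the limit of > 60000 nM in this assay, at which 3 of the 4 values shown sit. Benzoyl in place of phenyl at this position gives an at least 1.3-fold lower number from compound 3 to compound 4 (0.12 log units; that floor lies within the scatter), so even this first readable step has a floor that does not clear the usual scatter. The earlier steps shown here cannot be read, since both ends of each are limits.

As far as these compounds go, it remains open whether a carboxylic acid or an amide in place of the benzoyl would give a lower number. From the compounds shown here alone, whether benzoyl would also give a number with methoxy in place of dimethylamino is likewise open.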